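The source may report more compounds than this note shows. Statements on the series, on what has been measured and on what is new or still open speak of the compounds shown alone.

Three compounds share one core and differ in a single group: compound 1 (`Cc1ccc(Cn2c(N)nc3cc(Cl)c(Cl)cc32)cc1`) carries methyl, compound 2 (`CC(C)(C)c1ccc(Cn2c(N)nc3cc(Cl)c(Cl)cc32)cc1`) carries tert-butyl and compound 3 (`Nc1nc2cc(Cl)c(Cl)cc2n1Cc1ccc(F)cc1`) carries fluoro. In a functional assay on CEM-SS cells (Homo sapiens) for cytotoxicity (on this read-out higher numbers stand for weaker inhibition and lower numbers for stronger inhibition), compound 1 gives 40000 nM, compound 2 gives 27000 nM and compound 3 gives 30000 nM. Compound 2 therefore cannot be told apart from the other two, as all three numbers lie within the scatter of each other.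

Compound 4 (`CC(C)(C)c1ccc(Cn2c(Cl)nc3cc(Cl)c(Cl)cc32)cc1`) keeps the tert-butyl of compound 2 but differs elsewhere, with chloro in place of amino on an aromatic carbon, between two ring nitrogen atoms (chloro in place of amino on an aromatic carbon).

The measured steps are a 1.5-fold lower number from compound 1 to compound 2 (0.17 log units; within the scatter), a 1.3-fold lower number from compound 1 to compound 3 (0.12 log units; within the scatter) and a 1.1-fold higher number from compound 2 to compound 3 (0.05 log units; within the scatter). Among the measured compounds shown here, all three swap methyl, tert-butyl or fluoro, so none of them touches the amino group, and no measurement yet shows what replacing it does. They offer only weak guidance, and the uncertainty is wide in both directions. Starting from compound 2 at 27000 nM, no step beyond the scatter is expected in this assay. For compound 4 the expected step is a 1.4-fold lower number from compound 2 to compound 4 (0.13 log units; within the scatter). Compound 4 is estimated at 20000 nM, with an expected range from 6000 nM to 60000 nM.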

Compound 4, half-maximal inhibitory concentration: > 100000 nM
Compound 4: no number, only a limit; the forecaster's own chance of this, stated with the estimate: 20%; middle value at least 5.0-fold (0.69 log units) from the limit.
By their numbers in this assay, from the lowest: compounds 2, 3 and 1 (each within the scatter of the next). At a limit, above all of these: compound 4.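

The earlier compounds shown here all keep the amino group and differ only in methyl, tert-butyl or fluoro, so they say nothing about the aromatic carbon between two ring nitrogen atoms. Compound 4 changes that carbon, and in this assay the swap of amino for chloro gives an at least 3.7-fold higher number from compound 2 to compound 4 (0.56 log units; beyond the scatter), which points to weaker inhibition. This position therefore responds to a change in a way that the swaps among methyl, tert-butyl and fluoro, all within the scatter, did not show. For compound 4 the result is a limit and not a number, so the step gives only a minimum size: the limit of > 100000 nM in this assay, at which 1 of the 4 values shown sits.

With chloro as the only replacement shown, and only alongside tert-butyl, the compounds cannot separate the effect of removing amino, with its hydrogen-bond donor and acceptor, from the effect of adding chloro. On these data alone, a methylamino group or a hydroxyl group at this position would help to separate the two, and it remains open whether the same swap gives a similar step alongside the methyl of compound 1 or the fluoro of compound 3.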